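Chloro-carboxyphenyl ether in the benzyl ketone series

The compounds below may be only part of what the source reports. "The series", "measured", "known", "first", "only" and "open" are said of these compounds alone.

Measured compounds:
compound 1 `Cc1c(OCCCCOc2ccc(C(=O)O)cc2F)ccc(C(=O)CC2CCCC2)c1O`, 639 nM
compound 2 `Cc1ccc(C(=O)O)cc1OCCCCOc1ccc(C(=O)CC2CCCC2)c(O)c1C`, 1290 nM

In an assay on HEK293 cells for positive allosteric modulation of metabotropic glutamate receptor 2 (Rattus norvegicus), read by thallium flux, with a stated time of 2.5 min (on this read-out higher numbers stand for an effect only at larger amounts of compound and lower numbers for an effect already at smaller amounts), compound 2 gives the highest of the two numbers, and compound 1 sits nearest at a 2.0-fold higher number from compound 1 to compound 2 (0.31 log units; beyond the scatter). Compound 3 `Cc1c(OCCCCOc2ccc(C(=O)O)c(Cl)c2)ccc(C(=O)CC2CCCC2)c1O` is not yet measured; it carries 4-carboxy-3-chlorophenyl in place of 5-carboxy-2-methylphenyl on an oxygen on a saturated carbon. Among the compounds with values here, the only step that bears on this change is a 2.0-fold higher number from compound 1 to compound 2 (0.31 log units; beyond the scatter), which replaced a 4-carboxy-halophenyl with the 5-carboxy-2-methylphenyl group. Compound 3 returns to a 4-carboxy-halophenyl, so the author expects the number to move back toward that of compound 1, a step of about a 1.8-fold lower number from compound 2 to compound 3 (0.27 log units; within the scatter) in this assay. Compound 3 is therefore estimated at 700 nM, with a range from 300 nM to 1600 nM.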

Compound 3, half-maximal effective concentration: 510 nM
Beside the measured number, compound 3's estimate is 1.4-fold (0.14 log units) above it, within the range that was stated.
By their numbers in this assay, from the lowest: compounds 3 and 1 (each within the scatter of the next); then compound 2.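

In this assay, 4-carboxy-3-chlorophenyl in place of 5-carboxy-2-methylphenyl on this oxygen gives a 2.5-fold lower number from compound 2 to compound 3 (0.40 log units; beyond the scatter) and thus a change beyond the scatter. Exchanging 4-carboxy-2-fluorophenyl for 4-carboxy-3-chlorophenyl gives only a 1.3-fold lower number from compound 1 to compound 3 (0.10 log units; within the scatter) and so separates neither group from the other. Nothing available explains either step.

The compounds shown leave open what an amide or a tetrazole would do in place of the carboxylic acid. They also leave open how a 4-carboxy-3-methylphenyl group would compare with 4-carboxy-3-chlorophenyl.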